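The source may report more compounds than this note shows. Statements on the series, on what has been measured and on what is new or still open speak of the compounds shown alone.

Among the compounds with values here, in a functional assay on A549 cells (Homo sapiens) for inhibition, read by MTT assay, with a stated time of 48 h (on this read-out higher numbers stand for weaker inhibition and lower numbers for stronger inhibition), compound 2 (`COc1ccc(N(C)c2nc(C)nc3ccccc23)cc1C[Se]C#N`) gives 98 nM, the lower of the two numbers measured so far. Within the data shown here, the only other measured compound, compound 1 (`COc1ccc(N(C)c2nc(C)nc3ccccc23)cc1OCCCCCC[Se]C#N`), gives 5520 nM. Compound 3 (`COc1ccc(N(C)c2nc(C)nc3ccccc23)cc1OCCCCC[Se]C#N`) is not yet measured. It differs from compound 2 by a group of 9 heavy atoms (6 carbon, 1 nitrogen, 1 oxygen, 1 selenium; no ring) in place of a group of 4 heavy atoms (2 carbon, 1 nitrogen, 1 selenium; no ring), on an aromatic carbon, and the change sits ortho to a methoxy group. Among the measured compounds shown here, one measured step bears on this: a 56-fold lower number from compound 1 to compound 2 (1.75 log units; beyond the scatter), which is large and beyond the scatter. That step replaces a group of 10 heavy atoms with a group of 4 heavy atoms. Compound 3 carries a group of 9 heavy atoms, close in size to the group in compound 1, so a large rise is expected in this assay, although a single step is thin support. The expected change is a 41-fold higher number from compound 2 to compound 3 (1.61 log units; beyond the scatter). For compound 3, the estimated value is 4000 nM, within an expected range of 1500 nM to 10000 nM.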

Compound 3, half-maximal inhibitory concentration: 2440 nM
Compound 3: the middle estimate sits 1.6-fold (0.21 log units) above what was measured, and the stated range covers the measured number.
By their numbers in this assay, from the lowest: compound 2; then compound 3; then compound 1.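

In this assay, a second chain attached through oxygen also sits far from the small group of compound 2, with a 25-fold higher number from compound 2 to compound 3 (1.40 log units; beyond the scatter) on this aromatic carbon, so the large gap is not peculiar to compound 1. Shortening that chain gives only a 2.3-fold lower number from compound 1 to compound 3 (0.35 log units; beyond the scatter) as a modest gain, and the shorter chain keeps most of the gap to compound 2. No measurement shown here offers an explanation for either step.
On these data alone, compound 2 and compound 3 differ in both the oxygen link and the chain length, so it remains open which of these matters, and whether a still shorter chain attached through oxygen would approach compound 2. As far as these compounds go, it is also open whether an amine or a carboxylic acid at the chain end would change the number.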